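The compounds below may be only part of what the source reports. "The series", "measured", "known", "first", "only" and "open" are said of these compounds alone.

Measured compounds:
- compound 1 `O=C(O)c1ccc2c(O)c(C(=O)O)cnc2c1`: in an assay on isolated protein with malate dehydrogenase, mitochondrial (Sus scrofa) as the target (a higher number here means a weaker inhibitor, a lower number a stronger inhibitor), compound 1 gives 1070000 nM
- compound 2 `O=C(O)c1cnc2cc(OCCc3ccc(Br)cc3)ccc2c1O`: in this assay compound 2 gives 2510 nM

Of the compounds shown here, two have been measured. Compound 1 stands at the highest of the two numbers; compound 2 is the nearest, and the gap between them is far beyond the usual scatter, so compound 1 is clearly the weaker inhibitor of the pair. Within the data shown here, no step between two measured compounds differing in a single place is available, so the effect of any one change on the shared core of compound 1 is not yet known from these data.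

Compound 3 `NS(=O)(=O)c1ccc2c(O)c(C(=O)O)cnc2c1` has not been measured. It differs from compound 1 in one place: sulfamoyl in place of carboxy on an aromatic carbon. Among the measured compounds shown here, with no comparable step on record, there is no basis for expecting a large move in either direction; a step from compound 1 to compound 3 of a 1.1-fold lower number from compound 1 to compound 3 (0.03 log units; within the scatter) is expected, which is within or close to the scatter. For compound 3 in this assay the estimated value is 1000000 nM, with a plausible range from 200000 nM to 5000000 nM.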

Compound 3, half-maximal inhibitory concentration: 955000 nM
Beside the measured number, compound 3's estimate is 1.0-fold (0.02 log units) above it; low and high end bracket the measured number.
By their numbers in this assay, from the lowest: compound 2; then compounds 3 and 1 (each within the scatter of the next).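

On the aromatic carbon that carries this group in the core of compound 1, this assay gives its first single-place step: a 1.1-fold lower number from compound 1 to compound 3 (0.05 log units; within the scatter). Carboxy and sulfamoyl therefore cannot be told apart here, even though sulfamoyl brings in sulfur and nitrogen and has one more double bond outside the aromatic rings, so on this core the reading does not depend on keeping carboxy at this place. No accompanying measurement bears on why the two groups read alike.

The compounds shown leave open whether this insensitivity extends to other groups on the same carbon, such as a primary carboxamide, a nitrile, a methyl ester or a plain hydrogen, and whether any of these would move the number beyond the scatter in this assay. They also leave open whether sulfamoyl and carboxy would remain interchangeable if another place on the core were changed at the same time, or whether substituents on the sulfamoyl nitrogen, such as a methyl group or a longer chain, would shift the value.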